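The source may hold more compounds than are shown below. What is called first, only, known or untested is meant among the compounds shown, and "the series" means these compounds.

In a functional assay on SW-620 cells (Homo sapiens) for cytotoxicity, read by MTT assay, with stated times of 4 h and 72 h, tested at 5 uM (a lower number here means a stronger inhibitor, a higher number a weaker inhibitor), compound 1 `Cc1cc(Nc2ccc(C(=O)/C=C/c3ccc4ccccc4c3)cc2)n2nc(SCc3ccccc3C(F)(F)F)nc2n1` gives 1240 nM. Its nearest neighbour among the measured compounds is compound 2 `Cc1cc(Nc2ccc(C(=O)/C=C/c3ccc4ccccc4c3)cc2)n2nc(SCc3ccccc3[N+](=O)[O-])nc2n1`, which in this assay gives 960 nM; the two differ only by nitro in place of trifluoromethyl on an aromatic carbon, and the step of a 1.3-fold lower number from compound 1 to compound 2 (0.11 log units; within the scatter) leaves the pair indistinguishable. Compound 3 `Cc1cc(Nc2ccc(C(=O)/C=C/c3ccc4ccccc4c3)cc2)n2nc(SCc3cccc([N+](=O)[O-])c3)nc2n1` has not yet been measured in this assay. It differs from compound 1 by 3-nitrophenyl in place of 2-(trifluoromethyl)phenyl on a saturated chain carbon bound to a sulfur. Within the data shown here, the one measured step that bears on this, a 1.3-fold lower number from compound 1 to compound 2 (0.11 log units; within the scatter), shows that exchanging trifluoromethyl for nitro at the same place alters the number little; no measured step covers the shift of the nitro to another place on that ring. Compound 3 is therefore expected to give a number close to that of compound 1, a step of a 1.2-fold lower number from compound 1 to compound 3 (0.07 log units; within the scatter) with nothing beyond the scatter. The estimate for compound 3 is 1050 nM, with a range from 500 nM to 2300 nM.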

Compound 3, half-maximal inhibitory concentration: 790 nM
Beside the measured number, compound 3's estimate is 1.3-fold (0.12 log units) above it; measured number inside the range.
By their numbers in this assay, from the lowest: compounds 3, 2 and 1 (each within the scatter of the next).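

In this assay, among these compounds, moving the nitro group, with 3-nitrophenyl in place of 2-nitrophenyl on a saturated chain carbon bound to a sulfur, gives a 1.2-fold lower number from compound 2 to compound 3 (0.08 log units; within the scatter), so this position now has a first reading for where the nitro group sits on the ring, and that reading does not separate the two compounds. The change of both group and place together, 3-nitrophenyl in place of 2-(trifluoromethyl)phenyl, gives a 1.6-fold lower number from compound 1 to compound 3 (0.20 log units; within the scatter), which likewise leaves the pair indistinguishable. Nothing measured here offers an account of this result.

All three compounds keep a substituted benzyl group on the sulfur and carry only nitro or trifluoromethyl on its ring. As far as these compounds go, whether an amine or a carboxylic acid on that ring, or a longer chain in place of the benzyl group, would move the number beyond the scatter remains open.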